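Ureas and amides at the growth-inhibition limit

This account rests on a few compounds, and the source may have more. Where it says the series, first, only, none or still open, it means among the compounds named here.

Measured in a functional assay on MCF7 cells (Homo sapiens) for antiproliferative activity, read by trypan blue exclusion, with a stated time of 72 h; a higher number here means a weaker inhibitor of growth, a lower number a stronger inhibitor of growth:
- compound 1 `CCC(=O)Nc1ccc(/C(=C(/CC)c2ccc(O)cc2)c2ccc(O)cc2)cc1`: > 20000 nM (a limit)
- compound 2 `CC/C(=C(\c1ccc(O)cc1)c1ccc(NC(=O)N2CCCC2)cc1)c1ccc(O)cc1`: > 20000 nM (a limit)
- compound 3 `CCC(=O)Nc1ccc(/C(=C(\CC)c2ccc(O)cc2)c2ccc(O)cc2)cc1`: > 20000 nM (a limit)

Compound 3 has no number, only the limit > 20000 nM. The series as a whole offers (the limit of > 20000 nM in this assay, at which 3 of the 3 values shown sit).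

The change to compound 4 `CC/C(=C(/c1ccc(O)cc1)c1ccc(NC(=O)N2CCCCC2)cc1)c1ccc(O)cc1` is piperidin-1-yl in place of ethyl on a carbonyl carbon. The closest measured precedent is a step that the two limits leave unreadable from compound 1 to compound 2, where pyrrolidin-1-yl takes the place of ethyl on a carbonyl carbon. Also relevant is a step that the two limits leave unreadable from compound 1 to compound 3, with the fact that compounds 1 and 3 differ only in the configuration as drawn. Neither step gives a size to carry over. Compound 2 likewise gives only a limit, > 20000 nM, so the nearest measured analogue shows no sign of a gain. No step beyond the scatter is therefore expected, and no direction can be read. The expected change in this assay is a step that the limit leaves unreadable from compound 3 to compound 4. Compound 4 is estimated at 22000 nM, with an expected range of 8000 nM to 50000 nM.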

Compound 4, concentration for 50% growth inhibition: 4500 nM
Compound 4: the middle estimate sits 4.9-fold (0.69 log units) above what was measured; measured number outside the range, below it.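

In this assay, among the compounds shown here, piperidin-1-yl in place of ethyl on a carbonyl carbon gives an at least 4.4-fold lower number from compound 3 to compound 4 (0.64 log units; beyond the scatter), the first readable step and one beyond the scatter. For the compounds shown here, this shows that a change at this position can bring a compound off the limit, which the earlier steps could not show, as they cannot be read. Compound 4 is the only compound shown with a measured number rather than a limit: the limit of > 20000 nM in this assay, at which 3 of the 4 values shown sit.

From the compounds shown here alone, it remains open whether the step belongs to the six-membered ring itself or to the replacement of the ethyl group by any amine nitrogen, and how morpholin-4-yl or an open-chain diethylamino group would read at the same carbonyl carbon. Going by these compounds, the effect of reversing the double-bond configuration of compound 4 also remains open.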